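A few compounds are considered here, and "the series" means these few. Any claim that something is new, unique, unknown or untested is made for them only; others in the source may bear on it.

In an ADME assay on A549 cells (Homo sapiens) for cytotoxicity, read by resazurin assay, with a stated time of 48 h (a lower number here means that less compound is tolerated, a higher number that more compound is tolerated), compound 1 (`O=C(Nc1ccc(NCc2ccc(C(F)(F)F)cc2)cc1Cl)c1cc(Cl)ccc1O`) gives 62700 nM and compound 2 (`O=C(Nc1ccc(NCc2cccnc2Cl)cc1Cl)c1cc(Cl)ccc1O`) gives 101000 nM, so compound 2 lies within the scatter of compound 1. Compound 3 (`O=C(Nc1ccc(NCc2ccc3cn[nH]c3c2)cc1Cl)c1cc(Cl)ccc1O`) differs from compound 2 as follows: 1H-indazol-6-yl in place of 2-chloropyridin-3-yl on a saturated chain carbon bound to a nitrogen on an aromatic ring. Going by the values given here, the one measured step at this place, a 1.6-fold higher number from compound 1 to compound 2 (0.21 log units; within the scatter), is small, and no measured compound carries 1H-indazol-6-yl. On that single step, no change beyond the scatter is expected in this assay. The expected change is a 1.6-fold lower number from compound 2 to compound 3 (0.19 log units; within the scatter). For compound 3 the estimated value is 65000 nM, with an expected range of 25000 nM to 140000 nM.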

Compound 3, half-maximal cytotoxic concentration: 45300 nM
Compound 3: the middle estimate sits 1.4-fold (0.16 log units) above what was measured, within the range that was stated.
By their numbers in this assay, from the lowest: compounds 3, 1 and 2 (each within the scatter of the next, the first and the last beyond it).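

Going by these compounds alone, at the saturated chain carbon bound to a nitrogen on an aromatic ring, 1H-indazol-6-yl gives the only step so far beyond the scatter in this assay (modest in size): a 2.2-fold lower number from compound 2 to compound 3 (0.35 log units; beyond the scatter). Measured against 4-(trifluoromethyl)phenyl, the same group stays within the scatter: a 1.4-fold lower number from compound 1 to compound 3 (0.14 log units; within the scatter). So the three groups are separated only by the gap between compound 2 and compound 3, and no measurement shown gives a reason for that step.

As far as these compounds go, whether an amine, a carboxylic acid or a longer chain at this place would move the number further remains open.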